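Benzylic replacement on the shared core against pancreatic cell growth

The compounds below may be only part of what the source reports. "The series", "measured", "known", "first", "only" and "open" are said of these compounds alone.

Measured compounds:
compound 1 `CCCCCCc1nc(N)n(CC(=O)Nc2ccccc2)c1-c1ccccc1Br`: 8600 nM
compound 2 `Nc1nc(CC2CCCC2)c(-c2ccccc2Br)n1CC(=O)Nc1ccccc1`: 61400 nM

Among the compounds with values here, in a functional assay on MIA PaCa-2 cells (Homo sapiens) for antiproliferative activity, read by MTT assay, with a stated time of 48 h (on this read-out higher numbers stand for weaker inhibition and lower numbers for stronger inhibition), compound 2 stands highest of the two numbers, with compound 1 as its only neighbour. Within the data shown here, the one measured step, a 7.1-fold higher number from compound 1 to compound 2 (0.85 log units; beyond the scatter), is the only guide here. Compound 3 `CC(C)(C)c1ccc(Cc2nc(N)n(CC(=O)Nc3ccccc3)c2-c2ccccc2Br)cc1` carries 4-(tert-butyl)phenyl in place of cyclopentyl on a saturated chain carbon bound to an aromatic carbon. That step replaced a chain by a small ring and cost clearly; a larger aromatic group is a different kind of change, so the direction is uncertain, and compound 3 is expected to move by a 2.0-fold lower number from compound 2 to compound 3 (0.31 log units; beyond the scatter). Compound 3 is estimated at 30000 nM, in the range 8000 nM to 120000 nM.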

Compound 3, half-maximal inhibitory concentration: 4900 nM
Compound 3: middle estimate off by 6.1-fold (0.79 log units), on the high side, outside the stated range (below it).
By their numbers in this assay, from the lowest: compounds 3 and 1 (each within the scatter of the next); then compound 2.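

In this assay, 4-(tert-butyl)phenyl in place of cyclopentyl on a saturated chain carbon bound to an aromatic carbon gives a 13-fold lower number from compound 2 to compound 3 (1.10 log units; beyond the scatter) and so shows that a ring group at this place need not cost activity. Set against pentyl, the same group gives a 1.8-fold lower number from compound 1 to compound 3 (0.24 log units; within the scatter) and so leaves those two compounds without an order. Nothing measured here accounts for the large step.

From the compounds shown here alone, whether plain phenyl would hold this level, or whether the tert-butyl group is needed, remains open. So does the effect of a longer chain or an amine on the ring at this place.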